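Groups on sulfur: the step to compound 4

The source may report more compounds than this note shows. Statements on the series, on what has been measured and on what is new or still open speak of the compounds shown alone.

Measured so far in a functional assay on SMMC-7721 cells (Homo sapiens) for inhibition, read by CCK-8 assay, with a stated time of 72 h, tested at 2 uM; a lower number here means less inhibition of growth, a higher number more inhibition of growth at the concentration tested
- compound 1 `COc1ccc(SCc2ccc(/C=C/C(=O)Nc3ccccc3N)cc2)cc1OC` gives 14.3%
- compound 2 `Cc1ccc(SCc2ccc(/C=C/C(=O)Nc3ccccc3N)cc2)cc1` gives 22%
- compound 3 `Nc1ccccc1NC(=O)/C=C/c1ccc(CSc2cccc3ccccc23)cc1` gives 3.7%

Compound 3 stands lowest of the three, and it alone carries naphthalen-1-yl on the sulfur. For the measured compounds named here, compound 4 `Nc1ccccc1NC(=O)/C=C/c1ccc(CSCCc2ccccc2)cc1` keeps the shared core and has phenethyl in place of naphthalen-1-yl on a sulfur as its only change. Going by the values given here, two measured steps bear on this, a number 10.6 percentage points lower from compound 1 to compound 3 (beyond the scatter) and a number 18.3 percentage points lower from compound 2 to compound 3 (beyond the scatter), both modest and both onto naphthalen-1-yl. A third, a number 7.7 percentage points higher from compound 1 to compound 2 (within the scatter), does not separate the other two groups on the sulfur. Among the compounds with values here, no measured compound carries phenethyl, so carrying these steps over is uncertain. Leaving naphthalen-1-yl is expected to give a modest rise in this assay, of a size similar to those steps. The expected change is a number 10.3 percentage points higher from compound 3 to compound 4 (beyond the scatter) in the estimate. For compound 4 the estimated value is 14%, with an expected range of 4% to 28% in this read-out.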

Compound 4, percent growth inhibition at one concentration: 14.7%
For compound 4 the middle estimate is 0.7 percentage points below the measured one; the range from low to high includes it.
By their numbers in this assay, from the lowest: compound 3; then compounds 1, 4 and 2 (each within the scatter of the next).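

In this assay, phenethyl, with its one six-membered aromatic ring of carbon only, does not share the low reading of naphthalen-1-yl, with a number 11 percentage points higher from compound 3 to compound 4 (beyond the scatter). It also cannot be separated from the two substituted phenyl groups on the sulfur, with a number 0.4 percentage points higher from compound 1 to compound 4 (within the scatter) and a number 7.3 percentage points lower from compound 2 to compound 4 (within the scatter), so among these four compounds only compound 3 stands apart, and no compound goes against this. Nothing at hand explains that difference.

Compound 3 alone carries two aromatic rings on the sulfur, so naphthalen-2-yl or biphenyl-4-yl would be needed to show whether the low reading follows the ring count or naphthalen-1-yl itself. As far as these compounds go, whether the sulfur tolerates a group with no aromatic ring, such as a plain hexyl chain or a chain ending in an amine or a carboxylic acid, also remains open.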